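The compounds below may be only part of what the source reports. "The series", "measured", "known", "first", "only" and "open" are said of these compounds alone.

Measured so far:
compound 1 `CC(C)S(=O)(=O)c1ccccc1NCC1=NCCN1`: 50%
compound 2 `CSc1ccc(Cl)cc1NCC1=NCCN1`: 92%
compound 3 `CS(=O)(=O)c1c(F)cccc1NCC1=NCCN1`: 93%

In a functional assay on CHO cells for agonist activity at Alpha-2C adrenergic receptor (Homo sapiens) (on this read-out lower numbers stand for smaller maximal responses and higher numbers for larger maximal responses), compound 1 gives 50%, the lowest of the three numbers; compound 2 gives 92% and compound 3 gives 93%, both beyond the scatter above compound 1, while the gap between compound 2 and compound 3 lies within the scatter. Compound 4 `CCS(=O)(=O)c1ccccc1NCC1=NCCN1` is not yet measured. Its difference from compound 1: hydrogen in place of methyl on a saturated chain carbon bound to a saturated chain carbon and a sulfonyl sulfur. For the measured compounds named here, no two measured compounds differ in a single place, so this step has no direct precedent. Some rise from compound 1 is expected, a number 20 percentage points higher from compound 1 to compound 4 (beyond the scatter) in this assay, partly because compound 3 also carries a sulfonyl group and gives 93%, though it differs from compound 1 in more than one place. Compound 4 is estimated at 70%, with a range from 45% to 95%.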

Compound 4, largest response reached (reported as maximum), in percent of the reference or control that the assay uses: 64%
Compound 4: middle estimate off by 6 percentage points, on the high side, within the range that was stated.
By their numbers in this assay, from the lowest: compound 1; then compound 4; then compounds 2 and 3 (each within the scatter of the next).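

In this assay, for the compounds shown here, going from isopropylsulfonyl to ethylsulfonyl gives a number 14 percentage points higher from compound 1 to compound 4 (beyond the scatter) and is the only single-place step so far. The maximal response therefore changes with the chain on the sulfonyl sulfur, even when the change is the loss of one methyl. One step sets no trend, and nothing at hand explains the rise.

Still open, going by these compounds, is whether a propyl, a cyclopropyl or a longer chain at this place would raise or lower the maximal response. Equally open, on these data alone, is how much of the response depends on the chain alone, with the rest of compound 4 unchanged.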